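Diester series on the shared core: stereo-unassigned analogue

A few compounds are considered here, and "the series" means these few. Any claim that something is new, unique, unknown or untested is made for them only; others in the source may bear on it.

The series carries paired amino acid carbamate esters on the shared core. Compound 1, `COc1cc(/C=C/C(=O)/C=C(O)/C=C/c2ccc(OC(=O)[C@H](CCC(N)=O)NC(=O)OCc3ccccc3)c(OC)c2)ccc1OC(=O)[C@H](CCC(N)=O)NC(=O)OCc1ccccc1`, in a functional assay on the whole organism (strain Wistar) for inhibition, with Rattus norvegicus as the target, read by paw edema, with stated times of 1 h and 4 h, at a dose of 10 mg/kg by the intraperitoneal route (a lower number here means less inhibition, a higher number more inhibition at the dose given (going by the name of the read-out)), gives 44%. Compound 2, `COc1cc(/C=C/C(=O)/C=C(O)/C=C/c2ccc(OC(=O)[C@H](CC(C)C)NC(=O)OCc3ccccc3)c(OC)c2)ccc1OC(=O)[C@H](CC(C)C)NC(=O)OCc1ccccc1`, in this assay gives 11%. Compound 3, `COc1cc(/C=C/C(=O)/C=C(O)/C=C/c2ccc(OC(=O)[C@H](C)NC(=O)OC(C)(C)C)c(OC)c2)ccc1OC(=O)[C@H](C)NC(=O)OC(C)(C)C`, in this assay gives 28%. On these three numbers compound 3 stands second highest: its nearest neighbour is compound 1, which lies higher by an amount beyond the scatter, and its furthest is compound 2, which lies lower by an amount beyond the scatter.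

Compound 4, `COc1cc(/C=C/C(=O)/C=C(O)/C=C/c2ccc(OC(=O)C(C)NC(=O)OC(C)(C)C)c(OC)c2)ccc1OC(=O)C(C)NC(=O)OC(C)(C)C`, is the next member. It differs from compound 3 as follows: the two compounds have the same atoms and bonds; at least one stereo element is drawn with a configuration in one of them and without one in the other: 2 of 5 stereo elements differ; a stereocentre at a saturated chain carbon is drawn S in compound 3 and without a configuration in compound 4; a stereocentre at a saturated chain carbon is drawn S in compound 3 and without a configuration in compound 4. For the measured compounds named here, no pair of measured compounds differs in this one respect, so the size of such a step is unknown. The atoms and bonds are identical and only two drawn configurations are left unassigned; no step beyond the scatter is expected in either direction in this assay. For compound 4 the expected value in this assay is 27%, with a range from 15% to 40%. The step that this estimate means, a number 1 percentage points lower from compound 3 to compound 4 (within the scatter), is expected to stay within the scatter.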

Compound 4, a percentage reported as inhibition, in the whole organism at one dose (the size of the read-out at that dose, not a potency): 40%
Estimate against measurement, compound 4: 13 percentage points below; the range from low to high includes it.
By their numbers in this assay, from the lowest: compound 2; then compound 3; then compounds 4 and 1 (each within the scatter of the next).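

The series now holds a step with no change in atoms and bonds: a number 12 percentage points higher from compound 3 to compound 4 (beyond the scatter) in this assay. For the compounds shown here, compounds 1, 2 and 3 differ in more than one place and gave no step, so this is the first sign that the number at these two saturated chain carbons can move while the ester and carbamate groups stay fixed. The only recorded difference within the pair is one of drawing: the fact that one of compounds 3 and 4 is drawn with a defined configuration and the other without, at the place where they differ

The structures do not tell whether compound 4 is a mixture of configurations or a single form, and no analogue drawn with the opposite configuration at these carbons is shown to settle it. Also open, as far as these compounds go, is whether a step of this kind would persist with a free amine in place of the carbamate.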